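Anilide in place of imine at the ring carbon

The source may hold more compounds than are shown below. What is called first, only, known or untested is meant among the compounds shown, and "the series" means these compounds.

Within the data shown here, of the three compounds measured so far, compound 3 `COc1ccc(/C=N/C2=C(C#N)C3C(N4CCCC4)CCCCN3C(=O)N2c2ccccc2)cc1` stands highest in a functional assay on the whole organism (strain albino) for inhibition, with Rattus norvegicus as the target, read by paw edema, with a stated time of 1 h, at a dose of 20 mmol/kg by the intraperitoneal route (a higher number here means more inhibition at the dose given (going by the name of the read-out), a lower number less inhibition), with compound 3 giving 59.1%. Compound 1 `N#CC1=C(NCC(=O)N2CCCC2)N(c2ccccc2)C(=O)N2CCCCC(N3CCCC3)C12` gives 40.1%, and compound 2 `N#CC1=C(NCN2CCCCC2)N(c2ccccc2)C(=O)N2CCCCC(N3CCCC3)C12` gives 29.7%. The step of a number 19 percentage points higher from compound 1 to compound 3 (beyond the scatter) and the step of a number 29.4 percentage points higher from compound 2 to compound 3 (beyond the scatter) both run toward the aromatic group on the double-bonded ring carbon, while the step of a number 10.4 percentage points lower from compound 1 to compound 2 (beyond the scatter) runs the other way.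

Compound 4 `N#CC1=C(NC(=O)c2ccccc2O)N(c2ccccc2)C(=O)N2CCCCC(N3CCCC3)C12` is the compound not yet measured. It differs from compound 3 in one place: a group of 10 heavy atoms (7 carbon, 1 nitrogen, 2 oxygen; one six-membered aromatic ring of carbon only) in place of a group of 10 heavy atoms (8 carbon, 1 nitrogen, 1 oxygen; one six-membered aromatic ring of carbon only), on a double-bonded ring carbon. The new group keeps the six-membered aromatic ring of carbon only but joins it through a carbonyl and an amino group, and brings two hydrogen-bond donors where the group that leaves has none. The two steps into compound 3 show that an aromatic group at this carbon gave more inhibition than the saturated ring groups of compound 1 and compound 2; whether an amide link holds that gain is not shown by any measured pair. He therefore expects a step of a number 13.1 percentage points lower from compound 3 to compound 4 (beyond the scatter), a modest fall toward the level of compound 1, and estimates compound 4 at 46%, with a range from 28% to 64%.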

Compound 4, a percentage reported as inhibition, in the whole organism at one dose (the size of the read-out at that dose, not a potency): 44.7%
The estimate for compound 4 lay 1.3 percentage points above the measured number; the range from low to high includes it.
By their numbers in this assay, from the lowest: compound 2; then compounds 1 and 4 (each within the scatter of the next); then compound 3.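

In this assay, keeping the six-membered aromatic ring of carbon only on the double-bonded ring carbon did not keep the level of compound 3: joining it as ((2-hydroxyphenyl)carbonyl)amino gave a number 14.4 percentage points lower from compound 3 to compound 4 (beyond the scatter), so at this position the ring alone does not settle the read-out and the group that carries it counts as well. On the amine nitrogen, (2-hydroxyphenyl)carbonyl gave a number 15 percentage points higher from compound 2 to compound 4 (beyond the scatter) when it replaced (piperidin-1-yl)methyl, which shows that some of the advantage over that group survives the change, whereas replacing ((pyrrolidin-1-yl)carbonyl)methyl gave a number 4.6 percentage points higher from compound 1 to compound 4 (within the scatter), so these two groups cannot be told apart here. Nothing in the data at hand gives a reason for any of these steps.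

The compounds shown leave open what a plain benzoyl group on the amine nitrogen, without the hydroxyl, or a 2-methoxyphenyl carbonyl group would give, so the hydroxyl cannot be separated from the carbonyl link. Each number also comes from a single dose, which leaves open whether the same order would hold at other doses.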